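Removing the (1-bromoethenyl)carbonyl group: notes on compound 4

The source may hold more compounds than are shown below. What is called first, only, known or untested is meant among the compounds shown, and "the series" means these compounds.

Measured so far:
- compound 1 `C=C(Br)C(=O)Nc1cccc(-c2cn3nc(Cc4ccccc4)sc3n2)c1`: 4500 nM in a functional assay on HeLa cells (Homo sapiens) for inhibition, read by cell counting, with a stated time of 4 days; a higher number here means a weaker inhibitor, a lower number a stronger inhibitor
- compound 2 `Nc1cccc(-c2cn3nc(Cc4ccccc4)sc3n2)c1`: in this assay compound 2 gives 24000 nM
- compound 3 `C=C(Br)C(=O)Nc1cccc(-c2cn3nc(-c4cccc(OC)c4)sc3n2)c1`: in this assay compound 3 gives 1100 nM

Two changes have been measured. The first is hydrogen in place of (1-bromoethenyl)carbonyl on a nitrogen on an aromatic ring, which gave a 5.3-fold higher number from compound 1 to compound 2 (0.73 log units; beyond the scatter). The second is 3-methoxyphenyl in place of benzyl on an aromatic carbon, which gave a 4.1-fold lower number from compound 1 to compound 3 (0.61 log units; beyond the scatter). Compound 3 therefore holds the lowest number of the three, with both steps to it beyond the scatter.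

Compound 4 `COc1cccc(-c2nn3cc(-c4cccc(N)c4)nc3s2)c1` has not been measured. It differs from compound 3 by hydrogen in place of (1-bromoethenyl)carbonyl on a nitrogen on an aromatic ring. This is the same change already seen from compound 1 to compound 2: the group that leaves, the hydrogen that enters and the place on a nitrogen on an aromatic ring whose other neighbours are aromatic carbon are described in the same words for both pairs. The two cores differ by 3-methoxyphenyl in place of benzyl on an aromatic carbon.

For the measured compounds named here, since the pair compound 1 and compound 2 is the only measured instance of this change, the expectation for compound 4 rests on it alone. The step from compound 3 to compound 4 is expected to be a 5.3-fold higher number from compound 3 to compound 4 (0.72 log units; beyond the scatter), set beside the measured 5.3-fold higher number from compound 1 to compound 2 (0.73 log units; beyond the scatter), and it starts from the value of compound 3, 1100 nM. Compound 4 is thus estimated at 5800 nM in this assay, with an expected range from 2500 nM to 15000 nM.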

Compound 4, half-maximal inhibitory concentration: 230000 nM
For compound 4 the middle estimate is 40-fold (1.60 log units) below the measured one; measured number outside the range, above it.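

In this assay, hydrogen in place of (1-bromoethenyl)carbonyl on the core of compound 3 gives a 210-fold higher number from compound 3 to compound 4 (2.32 log units; beyond the scatter), so the number rises on both cores but the size of the change does not carry from one core to the other: the same change on two cores in this assay, a 5.3-fold higher number (0.73 log units; beyond the scatter) from compound 1 to compound 2 and a 210-fold higher number (2.32 log units; beyond the scatter) from compound 3 to compound 4, 39-fold (1.59 log units) apart, beyond the scatter of two such steps

The order of the two cores also reverses between the pairs: with the (1-bromoethenyl)carbonyl group, compound 1 gives 4500 nM and compound 3 gives 1100 nM, while with the free amino group, compound 2 gives 24000 nM and compound 4 gives 230000 nM. This shows that the 3-methoxyphenyl and benzyl groups do not act independently of the group on the nitrogen in this series, but two pairs cannot show the reason for the gap, nor how large the change would be on any third core.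

The compounds shown leave open whether the large step belongs to 3-methoxyphenyl alone or would also appear with a plain phenyl or a 2-phenylethyl group on that aromatic carbon. They also leave open whether an acetyl or a propenoyl group on the nitrogen would give the same gap between the two cores.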